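The compounds below may be only part of what the source reports. "The series", "measured", "known", "first", "only" and "open" are said of these compounds alone.

Measured in a functional assay on HL-60 cells (Homo sapiens) for inhibition, read by MTT assay, with a stated time of 72 h; on this read-out higher numbers stand for weaker inhibition and lower numbers for stronger inhibition:
- compound 1 `CCO[C@@H]1C=CC(=O)[C@@H](CO)O1`: 3500 nM
- compound 2 `COCCOCCOCCO[C@@H]1C=CC(=O)[C@@H](CO)O1`: 7900 nM

Compound 1 holds the lower of the two numbers, and the gap to compound 2 lies beyond the usual scatter. Next in line is compound 3 `C#CCCO[C@@H]1C=CC(=O)[C@@H](CO)O1`, not yet measured. It differs from compound 1 by ethynyl in place of hydrogen on a saturated chain carbon, two bonds along the chain from an oxygen on a saturated carbon, which reads as ethyl to but-3-yn-1-yl. Within the data shown here, no measured pair shows this change, so the expectation is only loosely supported. Compound 2 carries a different chain on the shared core and still reads 7900 nM, so the two values show no large swing. No step beyond the scatter is expected in this assay, and the estimated change, a 1.1-fold lower number from compound 1 to compound 3 (0.04 log units; within the scatter), has no firm direction. For compound 3 the estimated value is 3200 nM, with an expected range of 1300 nM to 8000 nM.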

Compound 3, half-maximal inhibitory concentration: 2500 nM
Compound 3: the middle estimate sits 1.3-fold (0.11 log units) above what was measured, and the stated range covers the measured number.
By their numbers in this assay, from the lowest: compounds 3 and 1 (each within the scatter of the next); then compound 2.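

In this assay, ethynyl in place of hydrogen on a saturated chain carbon, two bonds along the chain from an oxygen on a saturated carbon, gives a 1.4-fold lower number from compound 1 to compound 3 (0.15 log units; within the scatter). Among these compounds, this is the only step read at this position so far, and it shows that the position accepts the ethyl to but-3-yn-1-yl change with no shift that can be told from the scatter. No measured evidence bears on this result.

The compounds shown leave open whether this flat step belongs to the triple bond or to the added chain length, which a plain butyl chain on the shared core would separate. They also leave open whether an amine or a carboxylic acid at the end of the chain would move the number beyond the scatter.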